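Amine substituent and tolerated concentration across the shared core

This account rests on a few compounds, and the source may have more. Where it says the series, first, only, none or still open, it means among the compounds named here.

The series keeps the core of compound 1 `CCCCOc1ccc(-c2nc3ncccn3c2NC2CCCC2)cc1` and varies only the group on a nitrogen on an aromatic ring. In a toxicity assay on A549 cells (Homo sapiens) for cytotoxicity, read by luminescence and CellTiter-Glo, with a stated time of 48 h (a lower number here means that less compound is tolerated, a higher number that more compound is tolerated), compound 1 gives 40000 nM. Compound 3 `CCCCOc1ccc(-c2nc3ncccn3c2NC(C)(C)CC(C)(C)C)cc1` gives 29000 nM in this assay. Compound 2 `CCCCOc1ccc(-c2nc3ncccn3c2NCCC)cc1` returns only a limit in this assay, > 100000 nM. Compound 2 thus stands at the limit of > 100000 nM in this assay, at which 1 of the 3 values shown sits. Both steps that touch it, an at least 2.5-fold higher number from compound 1 to compound 2 (0.39 log units; beyond the scatter) and an at least 3.4-fold lower number from compound 2 to compound 3 (0.53 log units; beyond the scatter), place compound 2 at the more tolerated end. Compound 4 `CCCCOc1ccc(-c2nc3ncccn3c2NCc2ccco2)cc1` differs from compound 2 by furan-2-yl in place of ethyl on a saturated chain carbon bound to a nitrogen on an aromatic ring. The entering group is larger than the leaving one, as in the two measured steps, so a downward step is expected; the expected step is an at least 1.8-fold lower number from compound 2 to compound 4 (0.25 log units; that floor lies within the scatter). For compound 4 the estimated value is 55000 nM, within 25000 nM to 120000 nM.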

Compound 4, half-maximal cytotoxic concentration: 78000 nM
Compound 4: middle estimate off by 1.4-fold (0.15 log units), on the low side; the range from low to high includes it.
By their numbers in this assay, from the lowest: compounds 3, 1 and 4 (each within the scatter of the next, the first and the last beyond it). At a limit, above all of these: compound 2.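

Among these compounds, the (furan-2-yl)methyl group is the first to place a five-membered aromatic ring with a hetero atom in the group on a nitrogen on an aromatic ring, and in this assay it gives a 2.7-fold higher number from compound 3 to compound 4 (0.43 log units; beyond the scatter), whereas a 2.0-fold higher number from compound 1 to compound 4 (0.29 log units; within the scatter) shows no separation. Against the propyl group the change reads only as a floor, an at least 1.2-fold lower number from compound 2 to compound 4 (0.10 log units; that floor lies within the scatter). Compound 2 remains a limit: the limit of > 100000 nM in this assay, at which 1 of the 4 values shown sits.

Still open, on these data alone, is how a carboxylic acid or a phenyl group at this place would read in this assay.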